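This account rests on a few compounds, and the source may have more. Where it says the series, first, only, none or still open, it means among the compounds named here.

- compound 1 `COc1ccc(S(=O)(=O)N2CCc3cccc(Nc4ccc(Cl)cc4)c32)cc1`: 463 nM
- compound 2 `COc1ccc(S(=O)(=O)N2CCc3cccc(Nc4ccc(F)c(F)c4)c32)cc1`: 726 nM
- compound 3 `COc1ccc(S(=O)(=O)N2CCc3cccc(Nc4ccc([N+](=O)[O-])cc4)c32)cc1`: 107 nM

All three values come from a functional assay on MKN-45 cells (Homo sapiens) for antiproliferative activity; on this read-out lower numbers stand for stronger inhibition and higher numbers for weaker inhibition. Compound 3 has the lowest number of the three, at 107 nM, and its gaps to both others lie beyond the scatter.

The next change leads to compound 4 `COc1ccc(S(=O)(=O)N2CCc3cccc(Nc4ccc(C(=O)O)cc4)c32)cc1`: carboxy in place of nitro on an aromatic carbon. In words, carboxy stands in place of nitro on an aromatic carbon, para to a large group.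

Going by the values given here, no measured compound carries carboxy, so the evidence is indirect. Two measured steps change the group at this place and end at the nitro compound: a 4.3-fold lower number from compound 1 to compound 3 (0.64 log units; beyond the scatter) and a 6.8-fold lower number from compound 2 to compound 3 (0.83 log units; beyond the scatter). Both are modest. The third, a 1.6-fold higher number from compound 1 to compound 2 (0.20 log units; within the scatter), lies within the scatter, so compound 1 and compound 2 serve as one reference level. In this small set, both compounds without nitro sit higher than compound 3. A modest step toward a higher number is therefore expected in this assay on leaving nitro, though a wide range is needed without a carboxy precedent.

That expectation amounts to an estimated 6.5-fold higher number from compound 3 to compound 4 (0.82 log units; beyond the scatter). For compound 4 the expected value is 700 nM, within an estimated range of 150 nM to 3500 nM.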

Compound 4, half-maximal inhibitory concentration: 1390 nM
Compound 4: middle estimate off by 2.0-fold (0.30 log units), on the low side; measured number inside the range.
By their numbers in this assay, from the lowest: compound 3; then compounds 1, 2 and 4 (each within the scatter of the next, the first and the last beyond it).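

Working notes on the position para to a large group: in this assay, the change from nitro to carboxy gives the largest step in the series so far, a 13-fold higher number from compound 3 to compound 4 (1.11 log units; beyond the scatter), even though the two groups match in heavy-atom count and in double bonds outside aromatic rings and differ in their hydrogen-bond donor and acceptor counts, so heavy-atom count alone does not set the read-out at this place. The carboxy compound also separates from the chloro compound, with a 3.0-fold higher number from compound 1 to compound 4 (0.48 log units; beyond the scatter), but not from the difluoro compound, with a 1.9-fold higher number from compound 2 to compound 4 (0.28 log units; within the scatter), so among the groups shown, the low number of compound 3 at 107 nM remains tied to nitro alone. The data offer no measured property of these groups that would account for this step.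

Still open, as far as these compounds go, is whether a nitrile, a primary amide or a methyl ester at this place would read close to compound 3 or close to compound 4. An amine at the same carbon would also show whether the read-out tolerates a group with a nitrogen directly on the ring other than nitro.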